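Removing a fluorine next to bromine: compound 4 estimate

The source may report more compounds than this note shows. Statements on the series, on what has been measured and on what is new or still open speak of the compounds shown alone.

Measured compounds:
Compound 1 `C=CCn1c(=O)/c(=C\c2cccc(C)c2)[nH]c(=O)/c1=C\c1ccccc1OC`: 19300 nM
Compound 2 `C=CCn1c(=O)/c(=C\c2cccc(F)c2)[nH]c(=O)/c1=C\c1ccccc1OC`: 9100 nM
Compound 3 `C=CCn1c(=O)/c(=C\c2ccc(F)c(Br)c2)[nH]c(=O)/c1=C\c1ccccc1OC`: "not active" (no number reported)

All three were tested in a functional assay on HeLa cells (Homo sapiens) for cytotoxicity, read by CCK-8 assay, with a stated time of 72 h; a higher number here means a weaker inhibitor, a lower number a stronger inhibitor. Compound 1 and compound 2 each gave a number, with a 2.1-fold lower number from compound 1 to compound 2 (0.33 log units; beyond the scatter). Compound 3 stands apart: in this assay compound 3 was reported as "not active" (no number reported), so no number is known for it and its place cannot be set against compound 1 or compound 2.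

Compound 4 `C=CCn1c(=O)/c(=C\c2cccc(Br)c2)[nH]c(=O)/c1=C\c1ccccc1OC` is not yet measured. It differs from compound 3 by hydrogen in place of fluoro on an aromatic carbon. For the measured compounds named here, no measured step shows this same change; the only measured step, from compound 1 to compound 2, concerns fluoro in place of methyl and so offers no direct guide. What remains is that compound 4 carries a single bromo on that ring, much as compound 1 and compound 2 each carry a single group there, and both of those gave a number.

Compound 4 is therefore expected to give a number in this assay, estimated at 15000 nM, with a range from 5000 nM to 60000 nM.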

Compound 4, half-maximal inhibitory concentration: 5400 nM
Compound 4: middle estimate off by 2.8-fold (0.44 log units), on the high side; the range from low to high includes it.
By their numbers in this assay, from the lowest: compounds 4 and 2 (each within the scatter of the next); then compound 1.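

Taking away the fluoro ortho to a bromo group separates a compound reported as not active in this assay from one with a number, so this place on the ring matters, yet compound 3 has no number and the size of that change cannot be read. Among the single groups on this ring, bromo in place of fluoro gives a 1.7-fold lower number from compound 2 to compound 4 (0.23 log units; within the scatter) and leaves those two compounds without an order, whereas bromo in place of methyl gives a 3.6-fold lower number from compound 1 to compound 4 (0.55 log units; beyond the scatter) and is a modest gain. Nothing at hand explains either result.

Still open, from the compounds shown here alone, is whether a fluoro at this same place would also cost the number with methyl in place of bromo. Also open, going by these compounds, is how an amine or a carboxylic acid on this ring would read in this assay and whether either would go beyond bromo.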